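Dropping a Bromo Group on a Second Core

A few compounds are considered here, and "the series" means these few. Any claim that something is new, unique, unknown or untested is made for them only; others in the source may bear on it.

Compound 1 `Cc1ccc(N2C(=O)CS/C2=N/N=C/c2c[nH]c3ccc(Br)cc23)cc1` and compound 2 `S=C(N/N=C/c1c[nH]c2ccc(Br)cc12)Nc1cccc2ccccc12` both carry a bromo group, but the difference between their two cores is not broken down here. In a functional assay on 786-0 cells (Homo sapiens) for inhibition, read by spectrophotometry and sulforhodamine B assay, with a stated time of 48 h (on this read-out lower numbers stand for stronger inhibition of growth and higher numbers for weaker inhibition of growth), compound 1 gives 39900 nM, while compound 2 gives 6560 nM. Compound 3 `S=C(N/N=C/c1c[nH]c2ccccc12)Nc1cccc2ccccc12` differs from compound 2 in one place (hydrogen in place of bromo on an aromatic carbon), and that change brought a 26-fold lower number from compound 2 to compound 3 (1.42 log units; beyond the scatter), so compound 3 gives 250 nM. Compound 4 `Cc1ccc(N2C(=O)CS/C2=N/N=C/c2c[nH]c3ccccc23)cc1` carries the same change on the core of compound 1 (hydrogen in place of bromo on an aromatic carbon), at the same place on the ring. For compound 4 in this assay the expected step is a 16-fold lower number from compound 1 to compound 4 (1.20 log units; beyond the scatter), because a 26-fold lower number from compound 2 to compound 3 (1.42 log units; beyond the scatter) shows what this change did on the other core, tempered somewhat since the two cores are not the same. Compound 4 is therefore estimated at 2500 nM, most likely between 600 nM and 12000 nM.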

Compound 4, concentration for 50% growth inhibition: 79100 nM
Compound 4: the middle estimate sits 32-fold (1.50 log units) below what was measured, outside the stated range (above it).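

In this assay, hydrogen in place of bromo on this core gives a 2.0-fold higher number from compound 1 to compound 4 (0.30 log units; within the scatter), so the change makes no clear difference here. The effect seen on the other core therefore did not carry over: the same change on two cores in this assay, a 26-fold lower number (1.42 log units; beyond the scatter) from compound 2 to compound 3 and a 2.0-fold higher number (0.30 log units; within the scatter) from compound 1 to compound 4, 52-fold (1.72 log units) apart, beyond the scatter of two such steps. This shows that, for these two pairs, the size of the step depends on the core that carries it, but two pairs cannot show which part of the cores is responsible, or why.

The compounds shown leave open how a chloro group or an amine on that same aromatic carbon would behave on each core. They also leave open which of the two outcomes a third core would follow.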